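This account rests on a few compounds, and the source may have more. Where it says the series, first, only, none or still open, it means among the compounds named here.

Compounds measured in a functional assay on CFPAC-1 cells (Homo sapiens) for inhibition, read by MTT assay, with a stated time of 72 h; a lower number here means a stronger inhibitor, a higher number a weaker inhibitor:
compound 1 `O=c1cc(Cn2cc(CCCO)nn2)c2ccc(O)cc2o1`: > 100000 nM
compound 2 `O=c1cc(Cn2cc(-c3cc(F)cc(F)c3)nn2)c2ccc(O)cc2o1`: > 100000 nM
compound 3 `O=c1cc(Cn2cc(CNS(=O)(=O)c3ccc(Cl)cc3)nn2)c2ccc(O)cc2o1`: 81900 nM

Compound 1 stands at a limit of the assay, not at a number. Compound 2 also stands at a limit. Compound 3 is the only one of the three with a numeric value, and that value sits close to the limit shared by the other two, as the limit of > 100000 nM in this assay, at which 2 of the 3 values shown sit, shows. Among the compounds with values here, the one step measured from compound 1, a step that the two limits leave unreadable from compound 1 to compound 2, is therefore unreadable: both ends are limits, so neither its size nor its direction can be taken from the data.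

Compound 4 `O=c1cc(Cn2cc(CSC(=S)N3CCNCC3)nn2)c2ccc(O)cc2o1` differs from compound 1 as follows: a group of 9 heavy atoms (5 carbon, 2 nitrogen, 2 sulfur; one six-membered non-aromatic ring with 2 hetero atoms) in place of a group of 3 heavy atoms (2 carbon, 1 oxygen; no ring), on a saturated chain carbon bound to an aromatic carbon. Within the data shown here, no measured step changes this place, and the only step starting from compound 1 gives no size. The weak showing of compound 3, with its group of comparable bulk in this region, is the nearest point of reference. The expectation for this assay is no step beyond the scatter, that is, compound 4 is expected to remain near the limit; the estimated step is an at least 1.1-fold lower number from compound 1 to compound 4 (0.04 log units; that floor lies within the scatter). Compound 4 is thus estimated at 90000 nM, with a range from 35000 nM to 250000 nM.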

Compound 4, half-maximal inhibitory concentration: > 100000 nM
Compound 4 ended at the assay's limit; the forecaster's own chance of this, stated with the estimate: 55%; middle value at least 1.1-fold (0.04 log units) from the limit.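

Compound 4 sits at a limit in this assay, as compound 1 does, so the step between compound 1 and compound 4 cannot be read in size or direction: the limit of > 100000 nM in this assay, at which 3 of the 4 values shown sit.

The compounds shown leave open what size of step any group at this place gives: no pair differing in one place has numeric values at both ends.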